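Thiophene substituent and cytotoxicity in the camphor-amine series

The source may hold more compounds than are shown below. What is called first, only, known or untested is meant among the compounds shown, and "the series" means these compounds.

compound 1 `C[C@H]1[C@H](NCc2sccc2C2CCCCC2)C[C@H]2C[C@@H]1C2(C)C`: 1560 nM
compound 2 `CCCCc1ccsc1CN[C@@H]1C[C@H]2C[C@@H]([C@H]1C)C2(C)C`: 25000 nM

Going by the values given here, in an ADME assay on MDCK cells (Canis lupus familiaris) for cytotoxicity, read by microscopy, with a stated time of 48 h (a lower number here means that less compound is tolerated, a higher number that more compound is tolerated), compound 2 gives 25000 nM, the highest of the two numbers so far; its nearest neighbour is compound 1 at 1560 nM. Compound 3 `C[C@H]1[C@H](NCc2sccc2C2CCCC2)C[C@H]2C[C@@H]1C2(C)C` is not yet measured and differs from compound 2 by cyclopentyl in place of butyl on an aromatic carbon. Among the compounds with values here, the one step that bears on this is a 16-fold higher number from compound 1 to compound 2 (1.20 log units; beyond the scatter), where a ring gave way to a chain and the number rose sharply. Bringing a ring back, now cyclopentyl, is expected to move this assay down again, though the size is uncertain with no cyclopentyl analogue measured; the expected step is a 6.3-fold lower number from compound 2 to compound 3 (0.80 log units; beyond the scatter). Compound 3 is therefore estimated at 4000 nM, with a range from 1500 nM to 12000 nM.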

Compound 3, minimum cytotoxic concentration: 12500 nM
Compound 3: the middle estimate sits 3.1-fold (0.49 log units) below what was measured, outside the stated range (above it).
By their numbers in this assay, from the lowest: compound 1; then compounds 3 and 2 (each within the scatter of the next).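

A ring at this position does not by itself bring the low number in this assay: a 2.0-fold lower number from compound 2 to compound 3 (0.30 log units; within the scatter), so cyclopentyl and butyl cannot be told apart here. The change from the larger ring carries the effect, with an 8.0-fold higher number from compound 1 to compound 3 (0.90 log units; beyond the scatter), and among these three compounds only compound 1, with cyclohexyl, stands apart. Nothing available explains this difference.

Open, going by these compounds, is whether a phenyl ring or a hexyl chain on this aromatic carbon would fall with compound 1 or with compounds 2 and 3.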